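Swapping a Ring Substituent: Expected Lipophilicity of Compound 4

A few compounds are considered here, and "the series" means these few. Any claim that something is new, unique, unknown or untested is made for them only; others in the source may bear on it.

Measured compounds:
- compound 1, `CNC(=O)c1cc(C(=O)N[C@H]2CC[C@H](O)CC2)c([C@@H](C)c2ccc(Cl)cc2)o1`: 3.5
- compound 2, `CNC(=O)c1cc(C(=O)N[C@H]2CC[C@H](O)CC2)c([C@@H](C)c2cccc(F)c2)o1`: 4.1
- compound 3, `CNC(=O)c1cc(C(=O)NC(C)CO)n([C@@H](C)c2ccccc2)n1`: 2.8

In a physicochemical assay for lipophilicity (on this read-out higher numbers stand for higher lipophilicity and lower numbers for lower lipophilicity), compound 2 gives 4.1, the highest of the three numbers. Its nearest neighbour is compound 1 with 3.5, and the furthest is compound 3, built on a different core, with 2.8; both gaps lie beyond the scatter.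

Compound 4, `CNC(=O)c1cc(C(=O)N[C@H]2CC[C@H](O)CC2)c([C@@H](C)c2ccc(C)cc2)o1`, has not been measured. It differs from compound 2 in one place: 4-methylphenyl in place of 3-fluorophenyl on a saturated chain carbon bound to an aromatic carbon and a saturated chain carbon

For the measured compounds named here, the only step that touches this place is a number 0.60 log units higher from compound 1 to compound 2 (beyond the scatter), where one halogen-bearing ring replaced another. Going by the values given here, no step in the data exchanges a fluorine-bearing ring for a methyl-bearing ring, so the direction must be read cautiously from that single step. A small rise in this assay is expected for compound 4, with the step of a number 0.20 log units higher from compound 2 to compound 4 (within the scatter) likely within or just beyond the scatter. Compound 4 is therefore estimated at 4.3, within a range of 3.8 to 4.8.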

Compound 4, distribution coefficient: 3.4
Estimate against measurement, compound 4: 0.90 log units above; measured number outside the range, below it.
By their numbers in this assay, from the lowest: compound 3; then compounds 4 and 1 (each within the scatter of the next); then compound 2.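

In this assay, for the compounds shown here, 4-methylphenyl in place of 3-fluorophenyl gives a number 0.70 log units lower from compound 2 to compound 4 (beyond the scatter) and shows that this position can also lower the number, a direction the earlier compounds alone gave no sign of. Methyl in place of chloro on an aromatic carbon gives a number 0.10 log units lower from compound 1 to compound 4 (within the scatter) and so makes no clear difference here, leaving the 4-chlorophenyl and 4-methylphenyl compounds together and the 3-fluorophenyl compound apart from both. Nothing available explains this gap.

The 3-fluorophenyl and 4-methylphenyl groups differ both in the group they carry and in where it sits on the phenyl ring, so the two effects cannot yet be told apart. On the same core, 3-methylphenyl and 4-fluorophenyl would separate them.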